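Replacing one sulfonyl group on compound 1

This account rests on a few compounds, and the source may have more. Where it says the series, first, only, none or still open, it means among the compounds named here.

Compound 1 (`O=S(=O)(Nc1ccc(-c2nc3ccccc3o2)cc1)c1ccc(Cl)s1`) is tested in an ADME assay on HEK293 cells (Homo sapiens) for cytotoxicity, read by resazurin assay, with a stated time of 48 h (on this read-out higher numbers stand for lower toxicity in this test and lower numbers for higher toxicity in this test), and gives > 100000 nM there, which is a limit of the assay and not a number. Compound 2 (`O=S(=O)(Nc1ccc2oc(-c3ccccc3)nc2c1)c1cccs1`) is a second sulfonamide with a different build, and compound 2 gives 97000 nM as a measured number in this assay under the same conditions.

Compound 3 (`O=S(=O)(Nc1ccc(-c2nc3ccccc3o2)cc1)c1ccccc1O`) carries 2-hydroxyphenyl in place of 5-chlorothiophen-2-yl on a sulfonyl sulfur, while the rest of compound 1 stays as it is. Among the compounds with values here, no pair of measured compounds shows what a single change of this kind does, so any forecast here rests on little. Within the data shown here, with compound 2 at 97000 nM as the only real number, a modest move toward lower numbers, meaning somewhat higher toxicity, is expected, or else nothing beyond the usual scatter. The estimated step of an at least 1.4-fold lower number from compound 1 to compound 3 (0.15 log units; that floor lies within the scatter) is expected to be small. Compound 3 is expected to read 70000 nM in this assay with a range of 25000 nM to 100000 nM on this estimate.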

Compound 3, half-maximal cytotoxic concentration: > 100000 nM
Compound 3: only a limit was reported; the forecaster's own chance of this, stated with the estimate: 40%; middle value at least 1.4-fold (0.15 log units) away from the limit.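

In this assay, compound 1 and compound 3 each give only a limit and not a number, so no step between them can be read: the limit of > 100000 nM in this assay, at which 2 of the 3 values shown sit.

The compounds shown leave open whether 2-hydroxyphenyl in place of 5-chlorothiophen-2-yl on a sulfonyl sulfur changes this read-out at all, and by how much.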